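Halogen swap on the pendant phenyl of a carboxylic acid series

This account rests on a few compounds, and the source may have more. Where it says the series, first, only, none or still open, it means among the compounds named here.

Of the compounds shown here, three sharing a carboxylic acid bearing core have been measured, and a fourth awaits its number. Compound 1 `O=C(O)c1cc(-n2c(-c3ccccc3)cc3c2CCCC3)cc(Br)c1O` and compound 2 `O=C(O)c1cc(-n2c(-c3ccccc3)cc3c2CCCC3)cc(Cl)c1O` carry the halogen on the acid-bearing ring. In a functional assay on the whole organism (strain Wistar) for inhibition, with Rattus norvegicus as the target, read by paw edema, with stated times of 30 min and 3 h, at a dose of 200 mg/kg by the oral route (a lower number here means less inhibition, a higher number more inhibition at the dose given (going by the name of the read-out)), compound 1 gives 0%, and compound 2 gives 0%. The step between them, no change at the digits printed from compound 1 to compound 2 (within the scatter), is the change (chloro in place of bromo on an aromatic carbon). Compound 3 `O=C(O)c1cc(-n2c(-c3ccc(Br)cc3)cc3c2CCCC3)ccc1O` has the same atoms as compound 1 joined differently; the difference between the two cores is not broken down here. In this assay compound 3 gives 40%, the highest of the three, and its step to compound 1 and to compound 2 lies beyond the scatter.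

Compound 4 `O=C(O)c1cc(-n2c(-c3ccc(Cl)cc3)cc3c2CCCC3)ccc1O` is not yet measured. It differs from compound 3 by chloro in place of bromo on an aromatic carbon. This is the same kind of change as that from compound 1 to compound 2, but the place differs: there the halogen sat ortho to a hydroxy group and meta to a carboxy group and to a large group, whereas here it sits para to a large group. Because no change at the digits printed from compound 1 to compound 2 (within the scatter) showed no change within the scatter, a step of no change at the digits printed from compound 3 to compound 4 (within the scatter) is expected, and compound 4 is estimated at 40%, between 20% and 60%.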

Compound 4, a percentage reported as inhibition, in the whole organism at one dose (the size of the read-out at that dose, not a potency): 40%
Beside the measured number, compound 4's estimate shows no gap at the digits printed, within the range that was stated.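

In this assay the swap on the second core gives no change at the digits printed from compound 3 to compound 4 (within the scatter), and it agrees with the swap on the first core: the same change on two cores in this assay, no change at the digits printed (within the scatter) from compound 1 to compound 2 and no change at the digits printed (within the scatter) from compound 3 to compound 4, 0 percentage points apart, within the scatter of two such steps

Across these two pairs the change therefore carries from one core to the other with no visible effect on the read-out, even though the halogen sits at a different place in each pair. For the compounds shown here, this does not show that the two halogens are interchangeable in general: compound 1 gives 0% and compound 2 gives 0%, so only the pair of compound 3 and compound 4 tests the swap where inhibition is seen, and a reading at a single dose says nothing about potency.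

The compounds shown leave open whether a 4-fluorophenyl or a 4-methoxyphenyl would read like the 4-bromophenyl and the 4-chlorophenyl. They also leave open whether inhibition would survive with an amide or a methyl ester in place of the carboxylic acid.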